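Chloromethyl in place of vinyl: compound 2 to compound 3

This account rests on a few compounds, and the source may have more. Where it says the series, first, only, none or still open, it means among the compounds named here.

Compound 1 `C=CC(=O)N(Cc1cc(C)no1)c1nc(-c2ccccc2)cs1` gives > 30000 nM in a functional assay on HCT-116 cells (Homo sapiens) for antiproliferative activity, read by MTT assay, with a stated time of 72 h (on this read-out lower numbers stand for stronger inhibition and higher numbers for weaker inhibition), which is a limit and not a number. Compound 2 `C=CC(=O)N(Cc1cc(C)no1)c1nc(-c2ccccc2O)cs1` gives > 30000 nM in this assay, also a limit. Going by the values given here, the series so far stands at the limit of > 30000 nM in this assay, at which 2 of the 2 values shown sit.

Among the compounds with values here, the only measured step is a step that the two limits leave unreadable from compound 1 to compound 2, so it offers no size to carry forward, and no measured step covers the next change. Compound 3 `Cc1cc(CN(C(=O)CCl)c2nc(-c3ccccc3O)cs2)on1` has chloromethyl in place of vinyl on a carbonyl carbon.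

A readable value for compound 3 could lie only on the side of stronger inhibition, so any expected movement runs that way, on thin grounds. The expected change is an at least 5.0-fold lower number from compound 2 to compound 3 (0.69 log units; beyond the scatter). For compound 3 the estimated value in this assay is 6000 nM, with an expected range of 800 nM to 30000 nM.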

Compound 3, half-maximal inhibitory concentration: > 30000 nM
Compound 3: only a limit was reported; the forecaster's own chance of this, stated with the estimate: 35%; middle value at least 5.0-fold (0.69 log units) from the limit.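

Compound 3 gives > 30000 nM in this assay, which is a limit and not a number. The step from compound 2 to compound 3 therefore joins two limits and cannot be read. The compounds shown leave open how they rank and which change would give a readable value, since all stop at one limit: the limit of > 30000 nM in this assay, at which 3 of the 3 values shown sit.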